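From fluoro to dimethylamino: compound 2 to compound 3

This account rests on a few compounds, and the source may have more. Where it says the series, first, only, none or still open, it means among the compounds named here.

Of the compounds shown here, two have been measured so far in a functional assay on P388 cells (Mus musculus) for inhibition; a higher number here means a weaker inhibitor, a lower number a stronger inhibitor. Compound 1 (`O=C1/C(=C/c2ccc(F)cc2)Cc2ccccc21`) gives > 50000 nM, which is a limit of the assay and not a number. Compound 2 (`O=C1CCCCC/C1=C\c1ccc(F)cc1`) gives > 50000 nM, again a limit. Among the compounds with values here, compound 2 therefore has no numerical position, and no measured step is available between compounds differing in one place.

Compound 3 (`CN(C)c1ccc(/C=C2\CCCCCC2=O)cc1`) carries dimethylamino in place of fluoro on an aromatic carbon. Within the data shown here, with no measured step as a guide, only a modest move toward stronger inhibition is expected, and another limit is quite possible. The estimated step of an at least 1.6-fold lower number from compound 2 to compound 3 (0.22 log units; that floor lies within the scatter) is correspondingly uncertain. For compound 3 the expected value is 30000 nM, with an estimated range of 8000 nM to 50000 nM.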

Compound 3, half-maximal inhibitory concentration: 18800 nM
Beside the measured number, compound 3's estimate is 1.6-fold (0.20 log units) above it; low and high end bracket the measured number.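

In this assay, within the data shown here, dimethylamino in place of fluoro on an aromatic carbon gives an at least 2.6-fold lower number from compound 2 to compound 3 (0.42 log units; beyond the scatter), the first step that can be read. Among these compounds, compound 3 is also the first compound with a number rather than a limit, so this position on the six-membered aromatic ring can carry a change that brings the read-out into the measurable range. The size of the step remains only a floor because compound 2 stands at a limit of the assay: the limit of > 50000 nM in this assay, at which 2 of the 3 values shown sit.

Still open, going by these compounds, is whether the shift belongs to dimethylamino in particular, or whether a primary amine, methylamino or methoxy at the same place would also give a number. Also open, on these data alone, is whether dimethylamino would have a comparable effect on the core of compound 1.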